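The source may report more compounds than this note shows. Statements on the series, on what has been measured and on what is new or still open speak of the compounds shown alone.

Among the measured compounds shown here, compound 2 `Cc1ccc(C(=O)n2c(-c3cn(-c4ccccc4)nc3-c3ccc(C)cc3)nc3ccccc32)cc1` is one of two compounds measured in an ADME assay on HEK-293T cells (Homo sapiens) for cytotoxicity, read by MTT assay, with a stated time of 24 h; on this read-out lower numbers stand for higher toxicity in this test and higher numbers for lower toxicity in this test. In this assay compound 2 gives 176000 nM, and compound 1 `Cc1ccc(-c2nn(-c3ccccc3)cc2-c2nc3ccccc3n2C(=O)c2cccc(C)c2)cc1` gives 195000 nM; the step of a 1.1-fold lower number from compound 1 to compound 2 (0.04 log units; within the scatter) lies within the scatter, so compound 2 stands level with compound 1 rather than apart from it. Compound 3 `Cc1ccc(-c2nn(-c3ccccc3)cc2-c2nc3ccccc3n2C(=O)c2cccnc2)cc1` differs from compound 2 by pyridin-3-yl in place of 4-methylphenyl on a carbonyl carbon. For the measured compounds named here, the one measured step bears on it only loosely: it exchanged one methylphenyl ring for another on the same carbonyl carbon and moved the number within the scatter. Going by the values given here, no measured step puts a pyridin-3-yl on that carbonyl carbon, so the data give no direct guide to this exchange. On what is shown, a step beyond the scatter is not expected, and the estimated step is a 1.0-fold higher number from compound 2 to compound 3 (0.01 log units; within the scatter). Compound 3 is therefore expected to give about 180000 nM in this assay, with a range from 90000 nM to 360000 nM.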

Compound 3, half-maximal cytotoxic concentration: 189000 nM
Compound 3: the middle estimate sits 1.1-fold (0.02 log units) below what was measured, within the range that was stated.
By their numbers in this assay, from the lowest: compounds 2, 3 and 1 (each within the scatter of the next).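

In this assay, replacing 4-methylphenyl with pyridin-3-yl on the carbonyl carbon gives a 1.1-fold higher number from compound 2 to compound 3 (0.03 log units; within the scatter), and replacing 3-methylphenyl with the same group gives a 1.0-fold lower number from compound 1 to compound 3 (0.01 log units; within the scatter). The earlier pair had shown only that one methylphenyl ring could stand in for another at this place, whereas compound 3 extends this to a six-membered aromatic ring with a hetero atom and a hydrogen-bond acceptor, and all three compounds stand level in this read-out. No supporting measurement is available to account for this lack of separation.

As far as these compounds go, all three compounds carry a six-membered aromatic ring on this carbonyl carbon, so it remains open whether a non-aromatic group there, such as a short alkyl chain, or a ring bearing an amine or a carboxylic acid, would shift the number beyond the scatter. Because the compounds shown differ only on this carbonyl carbon, they also leave open how changes elsewhere on the shared core, such as on its phenyl or 4-methylphenyl rings, would read in this assay.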